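A few compounds are considered here, and "the series" means these few. Any claim that something is new, unique, unknown or untested is made for them only; others in the source may bear on it.

Measured so far in the series:

Compound 1 `CNc1nccn2c(Cc3ccc(F)cc3)nnc12` gives 25 mg/kg.
Compound 2 `Nc1nccn2c(Cc3ccc(F)cc3)nnc12` reaches only a limit of the assay, > 25 mg/kg.
Compound 3 `CNc1nccn2c(Cc3cc(F)ccc3F)nnc12` gives 4 mg/kg.

All three values come from a functional assay on the whole organism with Rattus norvegicus as the target, in the maximal electroshock model; on this read-out lower numbers stand for an effect already at smaller amounts and higher numbers for an effect only at larger amounts of compound. Within this set compound 3 stands lowest; its nearest measured neighbour is compound 1, and the gap between them lies beyond the usual scatter. How the core of compound 3 differs from that of compound 1 is not broken down here.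

One change does recur. Compound 1 becomes compound 2 by hydrogen in place of methyl on a nitrogen on an aromatic ring. The measured step is a number no lower from compound 1 to compound 2 (the limit leaves the size open); its size cannot be read, because the limit of > 25 mg/kg in this assay, at which 1 of the 3 values shown sits, cuts it off. The same change, at the same place, carries compound 3 to the not yet measured compound 4 `Nc1nccn2c(Cc3cc(F)ccc3F)nnc12`: hydrogen in place of methyl on a nitrogen on an aromatic ring.

Going by the values given here, the one measured instance points in the direction of a higher number, without telling how far. Compound 4 is therefore expected to sit above compound 3 in this assay, and the estimate for compound 4 is 15 mg/kg, somewhere between 6 mg/kg and 40 mg/kg. The step that this expectation means is a 3.8-fold higher number from compound 3 to compound 4 (0.57 log units; beyond the scatter). Because compound 2 was already reported as > 25 mg/kg, there is a fair chance that compound 4 too is returned only as a limit rather than as a number.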

Compound 4, dose for half-maximal effect: 7 mg/kg
The estimate for compound 4 lay 2.1-fold (0.33 log units) above the measured number; the range from low to high includes it.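

On the core of compound 3, going from methylamino to amino in this assay gives a 1.8-fold higher number from compound 3 to compound 4 (0.24 log units; within the scatter), so on this core the read-out does not separate the two compounds. Whether the same replacement of methyl by hydrogen on the nitrogen does the same on the core of compound 1 cannot be settled, since the size of that earlier step cannot be read and only its direction is available for comparison: the same change on two cores in this assay, a number no lower (the limit leaves the size open) from compound 1 to compound 2 and a 1.8-fold higher number (0.24 log units; within the scatter) from compound 3 to compound 4; the limit leaves it open whether they differ. For compound 2 the entry > 25 mg/kg is a limit of the assay and not a number, so the series shows that the change can be made on both cores, but it gives no measured size that could be carried from one core to the other, and it neither confirms nor rules out that the change behaves alike on both.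

The compounds shown leave open how this assay would read with an ethyl group, a longer chain or an acetyl group on that nitrogen in place of methyl or hydrogen. They also leave open whether the methylamino to amino change reads the same on a core carrying chlorine in place of fluorine.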